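The compounds below may be only part of what the source reports. "The series", "measured", "known", "first", "only" and "open" are said of these compounds alone.

Measured in an assay on HeLa cells for inhibition of sphingosine-1-phosphate transporter SPNS2 (Mus musculus), read by LC-MS, tested at 2 uM; on this read-out higher numbers stand for more inhibition at the one concentration tested (going by the name of the read-out) and lower numbers for less inhibition:
- compound 1, `CCCCCCCCCCc1ccc(-c2noc(CN)n2)cc1`: 62%
- compound 2, `CCCCCCCCCCc1ccc(-c2noc(CC3CNC3)n2)cc1`: 63%

Compound 2 carries the higher of the two numbers, but the step of a number 1 percentage points higher from compound 1 to compound 2 (within the scatter) lies within the scatter, so the two compounds cannot be told apart on this assay. Compound 3, `CCCCCCCCCCc1ccc(-c2noc(CC3CCNC3)n2)cc1`, is not yet measured. It differs from compound 2 in one place: pyrrolidin-3-yl in place of azetidin-3-yl on a saturated chain carbon bound to an aromatic carbon. Going by the values given here, the only measured step that bears on this spot is the one from the amino group to the azetidin-3-yl group on the same saturated chain carbon, and that step was within the scatter. With a further ring-containing group entering at the same place and no measured evidence of a shift, the expected step of no change at the digits printed from compound 2 to compound 3 (within the scatter) is none beyond the scatter. Compound 3 is therefore estimated at 63%, with a range from 48% to 78%.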

Compound 3, a percentage reported as inhibition, at one concentration (the size of the read-out at that concentration, not a potency): 44%
Beside the measured number, compound 3's estimate is 19 percentage points above it; the whole stated range lies above it.
By their numbers in this assay, from the lowest: compound 3; then compounds 1 and 2 (each within the scatter of the next).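

In this assay this place on the saturated chain carbon does not treat every amine group alike: a five-membered ring in place of a four-membered ring gives a number 19 percentage points lower from compound 2 to compound 3 (beyond the scatter). Set against the open-chain amino group, the same ring gives a number 18 percentage points lower from compound 1 to compound 3 (beyond the scatter), so the match between the amino and azetidin-3-yl groups does not extend to pyrrolidin-3-yl, and the position is sensitive to the group it carries. Nothing available explains why the number falls.

On these data alone, what remains open is whether a still larger ring, such as piperidin-4-yl, would lower the number further or restore it. Also open, as far as these compounds go, is whether the ring size or the placement of the ring nitrogen matters more, which a group such as pyrrolidin-2-yl could help to separate.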